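Oxazole linker swap in a thiophene sulfonylcarbamate series

The source may report more compounds than this note shows. Statements on the series, on what has been measured and on what is new or still open speak of the compounds shown alone.

Measured so far:
compound 1 `CCCCOC(=O)NS(=O)(=O)c1sc(CC(C)C)cc1-c1ccc(Cn2cccn2)cc1` 2.3 nM
compound 2 `CCCCOC(=O)NS(=O)(=O)c1sc(CC(C)C)cc1-c1ccc(Cn2ncnn2)cc1` 16 nM
compound 3 `CCCCOC(=O)NS(=O)(=O)c1sc(CC(C)C)cc1-c1ccc(C(=O)c2ncco2)cc1` 13.8 nM

In an assay on membranes from uterus for displacement of a labelled ligand from Angiotensin type II receptor (Sus scrofa), with a stated time of 1.5 h (on this read-out higher numbers stand for weaker inhibition and lower numbers for stronger inhibition), compound 3 stands second highest of the three numbers; the step of a 1.2-fold lower number from compound 2 to compound 3 (0.06 log units; within the scatter) lies within the scatter, while the step of a 6.0-fold higher number from compound 1 to compound 3 (0.78 log units; beyond the scatter) was modest but beyond it. Compound 4 `CCCCOC(=O)NS(=O)(=O)c1sc(CC(C)C)cc1-c1ccc(Cc2ncco2)cc1` differs from compound 3 by (1,3-oxazol-2-yl)methyl in place of (1,3-oxazol-2-yl)carbonyl on an aromatic carbon. Among the compounds with values here, no measured step exchanges a carbonyl for a methylene at this position; the nearest information is that the two methylene-linked azoles bracket compound 3: compound 1 gave 2.3 nM and compound 2 gave 16 nM. A modest step toward lower numbers is therefore expected for compound 4, a 2.0-fold lower number from compound 3 to compound 4 (0.29 log units; within the scatter), with wide uncertainty. Compound 4 is estimated at 7 nM, range 2 nM to 25 nM.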

Compound 4, inhibition constant: 3.9 nM
Estimate against measurement, compound 4: 1.8-fold (0.25 log units) above; measured number inside the range.
By their numbers in this assay, from the lowest: compounds 1 and 4 (each within the scatter of the next); then compounds 3 and 2 (each within the scatter of the next).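

In this assay, with the 1,3-oxazol-2-yl group held fixed, the linker exchange can be read alone: methylene for carbonyl gives a 3.5-fold lower number from compound 3 to compound 4 (0.55 log units; beyond the scatter) and so separates the pair beyond the scatter. With the methylene held, the azole also counts, since 1,3-oxazol-2-yl for 2H-tetrazol-2-yl gives a 4.1-fold lower number from compound 2 to compound 4 (0.61 log units; beyond the scatter) while 1,3-oxazol-2-yl for 1H-pyrazol-1-yl gives a 1.7-fold higher number from compound 1 to compound 4 (0.23 log units; within the scatter) and stays within the scatter. Nothing available explains these steps.

From the compounds shown here alone, whether the carbonyl exchange gives a like step with 1H-pyrazol-1-yl stays open. So does the effect of a hydroxyl or an amine on the linker carbon, or of a longer chain there.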